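Two Inactive Amides and a Ring-Closed Analogue

The compounds below may be only part of what the source reports. "The series", "measured", "known", "first", "only" and "open" are said of these compounds alone.

Compound 1, `CN(CC(=O)N1CCc2ccccc2C1)C(=O)c1ccc(S(C)(=O)=O)c([N+](=O)[O-])c1`, and compound 2, `CC(C)N(C(=O)C1CCN(C(=O)c2ccc(S(C)(=O)=O)c([N+](=O)[O-])c2)CC1)C(C)C`, share one core and differ only in the fragment attached to the second carbonyl. Both were tested in an assay on isolated protein for inhibition of thyroid hormone receptor beta (Homo sapiens), read by fluorescence polarization; on this read-out higher numbers stand for weaker inhibition and lower numbers for stronger inhibition. In this assay compound 1 gives only a limit, > 60000 nM, and not a number. In this assay compound 2 likewise reaches only a limit, > 60000 nM. Compound 2 therefore stands at the weak end of what this assay can report, as shown by the limit of > 60000 nM in this assay, at which 2 of the 2 values shown sit.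

Compound 3, `CC1Cc2ccccc2N1C(=O)C1CCN(C(=O)c2ccc(S(C)(=O)=O)c([N+](=O)[O-])c2)CC1`, has not yet been measured in this assay. It differs from compound 2 in a single place: 2-methyl-2,3-dihydro-1H-indol-1-yl in place of diisopropylamino on a carbonyl carbon. Going by the values given here, no measured pair in this small set shows a comparable change, so the direction of the step cannot be read from the data. The expected step of a number no higher from compound 2 to compound 3 (the limit leaves the size open) is none beyond the usual scatter, with another limit the most likely outcome. Compound 3 is expected to give about 60000 nM in this assay, within a range from 15000 nM to 60000 nM.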

Compound 3, half-maximal inhibitory concentration: > 60000 nM
Compound 3 ended at the assay's limit; the forecaster's own chance of this, stated with the estimate: 75%; the middle value sits exactly at the limit.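

Compound 2 and compound 3 both end at a limit and not at a number, so no step between them can be read: the limit of > 60000 nM in this assay, at which 3 of the 3 values shown sit.

The compounds shown leave open what true strength each one has, and whether any fragment on the second carbonyl can bring the shared core to a measurable value in this assay.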